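A few compounds are considered here, and "the series" means these few. Any claim that something is new, unique, unknown or untested is made for them only; others in the source may bear on it.

Going by the values given here, compound 1 `C=CCNC(=O)/C(C)=C(\C)c1ccc(Br)cc1` is one of two compounds measured in a toxicity assay on the whole organism (strain Icem-CET (SPF Caw)) for cytotoxicity, with Mus musculus as the target (a lower number here means that less compound is needed, a higher number that more compound is needed for the effect), where compound 1 gives 500 mg/kg. Its companion, compound 2 `C/C(C(=O)NC1CC1)=C(/C)c1ccc(Br)cc1`, has the allyl group on the amide nitrogen exchanged for a cyclopropyl group; in this assay compound 2 gives 600 mg/kg, and the step of a 1.2-fold higher number from compound 1 to compound 2 (0.08 log units; within the scatter) lies within the usual scatter, so the two numbers cannot be told apart.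

Compound 3 `C=CCNC(=O)/C(C)=C(\C)c1ccc(OC)cc1` differs from compound 1 in a different place: methoxy in place of bromo on an aromatic carbon. Among the compounds with values here, no measured step touches the aromatic ring, so the only step available, from compound 1 to compound 2, does not bear on this change, and the expectation rests on the observation that the one change tried so far moved nothing beyond the scatter. Compound 3 is therefore expected to show no step beyond the scatter, no change at the digits printed from compound 1 to compound 3 (within the scatter), with an estimated 500 mg/kg in this assay, between 250 mg/kg and 1000 mg/kg.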

Compound 3, dose for half-maximal effect: 300 mg/kg
Beside the measured number, compound 3's estimate is 1.7-fold (0.22 log units) above it; measured number inside the range.
By their numbers in this assay, from the lowest: compounds 3, 1 and 2 (each within the scatter of the next).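

Going by these compounds alone, the first change on the aromatic ring, methoxy in place of bromo para to a large group, gives a 1.7-fold lower number from compound 1 to compound 3 (0.22 log units; within the scatter) in this assay. The ring position therefore behaves like the amide nitrogen so far: neither shows a step beyond the scatter, even though methoxy brings a hydrogen-bond acceptor that bromo does not have. No measurement here speaks to what lies behind this result.

As far as these compounds go, it remains open whether an amine or a carboxylic acid in place of bromo on this aromatic carbon would produce a step beyond the scatter in this assay. The same question stands for a longer chain on the amide nitrogen, and for whether changes at the two places would act independently when combined in a single compound.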